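This account rests on a few compounds, and the source may have more. Where it says the series, first, only, none or still open, it means among the compounds named here.

Of the compounds shown here, three built on a shared core have been measured in a functional assay on B16-BL6 cells (Mus musculus) for cytotoxicity, read by MTT assay, with a stated time of 48 h; a lower number here means a stronger inhibitor, a higher number a weaker inhibitor. Compound 1, `CNC(=O)c1ccc(Sc2ccc(NC(=S)Nc3cccc(C)c3)cc2)nc1`, gives only a limit in this assay, > 100000 nM. Compound 2, `CNC(=O)c1ccc(Sc2ccc(NC(=S)Nc3ccc(F)c(F)c3)cc2)nc1`, gives 52600 nM in this assay. Compound 3, `CNC(=O)c1ccc(Sc2cccc(NC(=S)Nc3ccc(F)c(F)c3)c2)nc1`, gives 58200 nM in this assay, the higher of the two numbers, and its gap to compound 2 lies within the scatter. For the measured compounds named here, the single step measured between two compounds differing in one place, an at least 1.9-fold lower number from compound 1 to compound 2 (0.27 log units; that floor lies within the scatter), starts from a limit, (the limit of > 100000 nM in this assay, at which 1 of the 3 values shown sits), so its true size remains open.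

Compound 4, `CNC(=O)c1ccc(Sc2cccc(NC(=S)Nc3ccc(Cl)cc3)c2)nc1`, differs from compound 3 in one place: 4-chlorophenyl in place of 3,4-difluorophenyl on an amide-type nitrogen. The only measured step touching the aryl group on the amide-type nitrogen is an at least 1.9-fold lower number from compound 1 to compound 2 (0.27 log units; that floor lies within the scatter), and it does not reach beyond the scatter; an exchange of two fluorines for one chlorine has no measured counterpart among these compounds. No step beyond the scatter is therefore expected in this assay. Compound 4 is estimated to give 55000 nM, somewhere between 20000 nM and 150000 nM. The expected step, a 1.1-fold lower number from compound 3 to compound 4 (0.02 log units; within the scatter), stays within the scatter.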

Compound 4, half-maximal inhibitory concentration: 67500 nM
Compound 4: the middle estimate sits 1.2-fold (0.09 log units) below what was measured; the measured number falls inside the stated range.
By their numbers in this assay, from the lowest: compounds 2, 3 and 4 (each within the scatter of the next). At a limit, above all of these: compound 1.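

In this assay, for the compounds shown here, the exchange on the amide-type nitrogen gives a 1.2-fold higher number from compound 3 to compound 4 (0.06 log units; within the scatter), the first step at this place read between two numbers and not from a limit. It shows that 3,4-difluorophenyl and 4-chlorophenyl cannot be told apart at this position on the core of compound 3, since the step stays within the scatter. No measurement shown bears on a cause for this step.

On these data alone, whether an unsubstituted phenyl, a 4-methoxyphenyl or a 4-aminophenyl on the same nitrogen would move the number beyond the scatter remains open. As far as these compounds go, the size of the other step at this place also remains open, since compound 1 gives only a limit: the limit of > 100000 nM in this assay, at which 1 of the 4 values shown sits.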